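The source may report more compounds than this note shows. Statements on the series, on what has been measured and on what is new or still open speak of the compounds shown alone.

Compound 3 `COC(=O)C1=C(C)NC(C)=C(C(=O)OCCCl)C1c1cccc([N+](=O)[O-])c1` gives 26 nM in a functional assay on HEK293 cells for antagonist activity at Voltage-dependent L-type calcium channel subunit alpha-1C (Oryctolagus cuniculus), read by FLIPR (on this read-out higher numbers stand for weaker inhibition and lower numbers for stronger inhibition), the highest of the three numbers in hand. Compound 1 `CCCCC1=C(C(=O)OCC)C(c2cccc([N+](=O)[O-])c2)C(C(=O)OCC)=C(C)N1` gives 20 nM, within the scatter of compound 3, while compound 2 `CCOC(=O)C1=C(C)NC(COC(C)=O)=C(C(=O)OCC)C1c1cccc([N+](=O)[O-])c1` gives 10 nM, a gap beyond the scatter. Going by the values given here, the only step measured so far, a 2.0-fold lower number from compound 1 to compound 2 (0.30 log units; within the scatter), concerns a different place on the shared core and bears on the new change only loosely. Compound 4 `COC(=O)C1=C(C)NC(C)=C(C(=O)OC2Cc3ccccc3C2)C1c1cccc([N+](=O)[O-])c1` differs from compound 3 by 2,3-dihydro-1H-inden-2-yl in place of 2-chloroethyl on an oxygen next to a carbonyl group. Among the compounds with values here, no measured step alters the group on an ester oxygen, so the expectation rests on the narrow spread of the three numbers. For this change a step of a 1.4-fold lower number from compound 3 to compound 4 (0.16 log units; within the scatter) is expected, not beyond the scatter. The estimate for compound 4 is 18 nM, with a range of 6 nM to 55 nM.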

Compound 4, half-maximal inhibitory concentration: 72 nM
For compound 4 the middle estimate is 4.0-fold (0.60 log units) below the measured one, and the stated range ends below it.
By their numbers in this assay, from the lowest: compounds 2, 1 and 3 (each within the scatter of the next, the first and the last beyond it); then compound 4.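

In this assay, going by these compounds alone, 2,3-dihydro-1H-inden-2-yl in place of 2-chloroethyl on an oxygen next to a carbonyl group gives a 2.8-fold higher number from compound 3 to compound 4 (0.44 log units; beyond the scatter), the first measured step at this place. The number here therefore responds to the group on this oxygen, and the two-ring group carries a modest loss beyond the scatter. Nothing at hand accounts for this shift.

With only these two groups on this oxygen, the ring system and the heavy-atom count cannot be told apart. From the compounds shown here alone, a benzyl group or a longer chain ending in an amine at this place remains open.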